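The source may hold more compounds than are shown below. What is called first, only, known or untested is meant among the compounds shown, and "the series" means these compounds.

Compound 1 `C[C@@H](O)[C@H]1C(=O)N2C(C(=O)OCOC(=O)C3CCCCC3)=C(S[C@@H]3CN[C@H](C(=O)Nc4cccc(C(=O)O)c4)C3)[C@H](C)[C@H]12` gives in an ADME assay for metabolic stability, read by LC-MS, with a stated time of 3 h, at pH 6.5, tested at 50 uM (a lower number here means that less of the compound is left, a higher number that more of the compound is left), a limit of the assay, > 95%.
Compound 2 `CCOC(=O)C1=C(S[C@@H]2CN[C@H](C(=O)Nc3cccc(C(=O)O)c3)C2)[C@H](C)[C@@H]2[C@@H]([C@@H](C)O)C(=O)N12` gives a limit too, > 95%.
Compound 3 `CCC(CC)C(=O)OCOC(=O)C1=C(S[C@@H]2CN[C@H](C(=O)Nc3cccc(C(=O)O)c3)C2)[C@H](C)[C@@H]2[C@@H]([C@@H](C)O)C(=O)N12` gives a limit as well, > 95%.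

Compound 3 thus stands at the top edge of what this assay reports, and so do the other two values: the limit of > 95% in this assay, at which 3 of the 3 values shown sit. Compound 4 `CC(C)C(=O)OCOC(=O)C1=C(S[C@@H]2CN[C@H](C(=O)Nc3cccc(C(=O)O)c3)C2)[C@H](C)[C@@H]2[C@@H]([C@@H](C)O)C(=O)N12` differs from compound 3 by one change: isopropyl in place of pentan-3-yl on a carbonyl carbon. The steps measured so far, a step that the two limits leave unreadable from compound 1 to compound 2, a step that the two limits leave unreadable from compound 1 to compound 3 and a step that the two limits leave unreadable from compound 2 to compound 3, cannot be read in size, since both ends of each sit at a limit. No readable step therefore bears on the new change, and the expectation for compound 4 is simply that it stays at the same limit, an estimated a number no higher from compound 3 to compound 4 (the limit leaves the size open). For compound 4 the expected value is 95%, ranging from 85% to 100%.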

Compound 4, percent of the compound remaining: > 95%
Compound 4 gave a limit, no number; the forecaster's own chance of this, stated with the estimate: 80%; the middle value sits exactly at the limit.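

Among these compounds, compound 4 gives a limit, so no step among compound 1, compound 2, compound 3 and compound 4 can be read in size: the limit of > 95% in this assay, at which 4 of the 4 values shown sit. The compounds shown leave open whether any of them truly differs from the others in this assay and whether any change at this place would lower the percent remaining.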